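The source may report more compounds than this note shows. Statements on the series, on what has been measured and on what is new or still open speak of the compounds shown alone.

Measured so far in an ADME assay on Vero cells (Chlorocebus sabaeus) for cytotoxicity, read by MTT assay, with a stated time of 72 h; a lower number here means that less compound is tolerated, a higher number that more compound is tolerated:
- compound 2 `Cc1c(C(=O)CSCCNC(=O)c2ccccc2)[n+]([O-])c2ccccc2[n+]1[O-]`; compound 2 gives > 100 ug/mL, a limit of this assay.
- compound 3 `Cc1c(C(=O)CSCCNC(=O)c2ccc(F)cc2)[n+]([O-])c2ccccc2[n+]1[O-]`; compound 3 gives > 100 ug/mL, also a limit.
- compound 1 `CC(=O)NCCSCC(=O)c1c(C)[n+]([O-])c2ccccc2[n+]1[O-]`; compound 1 gives "not determined" (no result reported).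

Compound 3 thus stands only at a limit, not at a number. Of the three values shown, two sit at the limit of > 100 ug/mL in this assay, at which 2 of the 3 values shown sit, and the third has no number at all. Within the data shown here, the single measured step, a step that the two limits leave unreadable from compound 2 to compound 3, is unreadable, since both of its values are limits.

Compound 4 `COc1ccc(C(=O)NCCSCC(=O)c2c(C)[n+]([O-])c3ccccc3[n+]2[O-])cc1` differs from compound 3 by methoxy in place of fluoro on an aromatic carbon. Among the measured compounds shown here, no measured step bears readably on this change; the only one, a step that the two limits leave unreadable from compound 2 to compound 3, gives no size. Compound 4 is therefore expected to remain at the same limit as compound 3, the expected step that the limit leaves unreadable from compound 3 to compound 4 being none beyond the scatter. The estimate for compound 4 is 150 ug/mL, with a range from 70 ug/mL to 300 ug/mL.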

Compound 4, half-maximal cytotoxic concentration: > 100 ug/mL
Compound 4 was reported as a limit; the forecaster's own chance of this, stated with the estimate: 80%; the middle value is on the limit's open side.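

Compound 4 joins compound 2 and compound 3 at a limit, so no step among these three compounds can be read: the limit of > 100 ug/mL in this assay, at which 3 of the 4 values shown sit.

The compounds shown leave open how far each lies past that limit in this assay, and whether fluoro or methoxy in place of hydrogen changes the tolerated concentration at all.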